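The source may hold more compounds than are shown below. What is called first, only, known or untested is meant among the compounds shown, and "the series" means these compounds.

Measured in a functional assay on P388 cells (Mus musculus) for cytotoxicity, read by MTT assay, with a stated time of 72 h; on this read-out higher numbers stand for weaker inhibition and lower numbers for stronger inhibition:
- Compound 1 `C=C1CC[C@]23C(C(=O)OC)=CCC[C@H]2[C@]12C[C@H](c1ccoc1)O[C@H]2O[C@@H]3O`: >= 10000 nM, a limit
- Compound 2 `COC(=O)C1=CCC[C@@H]2[C@]13CC[C@H](C)[C@@]21C[C@H](c2ccoc2)O[C@H]1O[C@@H]3O`: >= 10000 nM, a limit

Neither compound gives a numerical value in this assay. Compound 2 reads >= 10000 nM, which is a limit and not a number. It shares this position with compound 1, as the record for the series shows: the limit of >= 10000 nM in this assay, at which 2 of the 2 values shown sit. How far compound 2 lies past the limit is therefore unknown.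

Compound 3 `COC(=O)C1=CCC[C@@H]2[C@]13CC[C@H](C)[C@@]21C[C@H](c2ccoc2)O[C@H]1O[C@H]3O` is the next compound to be tested. Compared with compound 2, the change is the two compounds have the same atoms and bonds and differ only in configuration as drawn: 1 of 7 stereo elements differ; a stereocentre at a saturated ring carbon is drawn S in compound 2 and R in compound 3: a stereocentre at a saturated ring carbon is drawn S in compound 2 and R in compound 3. The two compounds have the same atoms and bonds. Going by the values given here, no measured pair shows what such a change does in this assay.

Among the compounds with values here, the only guide is that compound 2 gives >= 10000 nM, so no step beyond the scatter is expected, and a further limit is the likeliest report. The expected change is a number no higher from compound 2 to compound 3 (the limit leaves the size open). Compound 3 is estimated at 10000 nM, with an expected range from 4000 nM to 30000 nM.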

Compound 3, half-maximal inhibitory concentration: >= 10000 nM
Compound 3 was reported as a limit; the forecaster's own chance of this, stated with the estimate: 75%; the middle value lies on the limit itself.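

In this assay compound 3 gives >= 10000 nM, which is a limit and not a number. No step from compound 2 to compound 3 can be read, because both values are limits: the limit of >= 10000 nM in this assay, at which 3 of the 3 values shown sit.

The compounds shown leave open whether the change of configuration at the saturated ring carbon has any effect in this assay.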